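A few compounds are considered here, and "the series" means these few. Any claim that something is new, unique, unknown or untested is made for them only; others in the source may bear on it.

Three compounds of the series carry numbers in a functional assay on HeLa cells (Homo sapiens) for cytotoxicity, with a stated time of 72 h; on this read-out higher numbers stand for weaker inhibition and lower numbers for stronger inhibition. Compound 1 `Clc1ccc(Cc2nn3c(Br)c(-c4ccc(Cl)cc4)nc3s2)cc1` reaches only a limit there, > 250000 nM. Compound 2 `O=Cc1c(-c2ccc(Cl)cc2)nc2sc(Cc3ccc(Cl)cc3)nn12` gives 16000 nM, and compound 3 `N#CSc1c(-c2ccc(F)cc2)nc2sc(Cc3ccc(Cl)cc3)nn12` gives 20000 nM; the numbers of compound 2 and compound 3 lie within the scatter of each other, so compound 3 cannot be set apart from compound 2 on the numbers shown. Within the data shown here, the single measured step, an at least 15-fold lower number from compound 1 to compound 2 (1.19 log units; beyond the scatter), concerns the shared core rather than the phenyl ring. Compound 4 `N#CSc1c(-c2ccc(Cl)cc2)nc2sc(Cc3ccc(Cl)cc3)nn12` differs from compound 3 by chloro in place of fluoro on an aromatic carbon. Among the measured compounds shown here, no measured step bears on this exchange, and the two compounds that differ in both the phenyl halogen and the core group are within the scatter of each other. The expected step is accordingly none beyond the scatter, a 1.3-fold lower number from compound 3 to compound 4 (0.12 log units; within the scatter). Compound 4 is estimated at 15000 nM in this assay, with a range from 5000 nM to 50000 nM.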

Compound 4, half-maximal inhibitory concentration: 20000 nM
For compound 4 the middle estimate is 1.3-fold (0.12 log units) below the measured one, and the stated range covers the measured number.
By their numbers in this assay, from the lowest: compounds 2, 3 and 4 (each within the scatter of the next). At a limit, above all of these: compound 1.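

The exchange of 4-fluorophenyl for 4-chlorophenyl gives no change at the digits printed from compound 3 to compound 4 (within the scatter). With the phenyl halogen now matched, the core group can be read alone: cyanosulfanyl in place of formyl gives a 1.3-fold higher number from compound 2 to compound 4 (0.10 log units; within the scatter), while cyanosulfanyl in place of bromo gives an at least 12-fold lower number from compound 1 to compound 4 (1.09 log units; beyond the scatter). That last step rests on compound 1, whose value is a limit: the limit of > 250000 nM in this assay, at which 1 of the 4 values shown sits.

Open, from the compounds shown here alone, is whether an amine or a carboxylic acid in place of cyanosulfanyl would separate from compound 4. Also open, going by these compounds, is whether a methoxy group in place of chloro on the phenyl ring would move the number.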